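Swapping methylsulfanyl for a selenium-bearing group on a shared core

The source may report more compounds than this note shows. Statements on the series, on what has been measured and on what is new or still open speak of the compounds shown alone.

Four compounds share a core in which a carbon with a double bond to nitrogen joins two amide-type nitrogens. Compound 2 `CS/C(=N\C(=O)c1ccco1)NC(=O)c1ccco1` carries a methylsulfanyl group on that carbon; compound 3 `O=C(/N=C(/NC(=O)c1ccco1)[Se]Cc1ccccc1)c1ccco1` carries instead (a group of 8 heavy atoms (7 carbon, 1 selenium; one six-membered aromatic ring of carbon only) in place of a group of 2 heavy atoms (1 carbon, 1 sulfur; no ring), on a carbon with a double bond to nitrogen). In a functional assay on MCF7 cells (Homo sapiens) for cytotoxicity, read by MTT assay, with a stated time of 72 h (on this read-out higher numbers stand for weaker inhibition of growth and lower numbers for stronger inhibition of growth), compound 2 reaches only a limit, > 100000 nM, which is the limit of > 100000 nM in this assay, at which 1 of the 3 values shown sits. Compound 3 gives 58000 nM in this assay. Compound 1 `CS/C(=N\C(=O)c1csc([N+](=O)[O-])c1)NC(=O)c1csc([N+](=O)[O-])c1` has other ring groups on its core; how its core differs from that of compound 2 is not broken down here. In this assay compound 1 gives 78100 nM. Compound 4 `O=C(/N=C(/NC(=O)c1csc([N+](=O)[O-])c1)[Se]Cc1ccccc1)c1csc([N+](=O)[O-])c1` is not yet measured and differs from compound 1 by a group of 8 heavy atoms (7 carbon, 1 selenium; one six-membered aromatic ring of carbon only) in place of a group of 2 heavy atoms (1 carbon, 1 sulfur; no ring), on a carbon with a double bond to nitrogen, the same change made between compound 2 and compound 3. The measured version of that change gave an at least 1.7-fold lower number from compound 2 to compound 3 (0.23 log units; that floor lies within the scatter). Because that step was an at least 1.7-fold lower number from compound 2 to compound 3 (0.23 log units; that floor lies within the scatter), a step of similar size, a 1.7-fold lower number from compound 1 to compound 4 (0.24 log units; within the scatter), is expected for compound 4. Compound 4 is therefore estimated to give about 45000 nM, most likely between 15000 nM and 100000 nM.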

Compound 4, concentration for total growth inhibition: 54100 nM
Estimate against measurement, compound 4: 1.2-fold (0.08 log units) below; the range from low to high includes it.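

In this assay, putting the selenium-bearing group in place of methylsulfanyl on the core of compound 1 gives a 1.4-fold lower number from compound 1 to compound 4 (0.16 log units; within the scatter). Neither this step nor the earlier one stands clear of the scatter, so the two cores give no sign that the change acts differently from one to the other, and no firm sign that it acts at all: the same change on two cores in this assay, an at least 1.7-fold lower number (0.23 log units; that floor lies within the scatter) from compound 2 to compound 3 and a 1.4-fold lower number (0.16 log units; within the scatter) from compound 1 to compound 4; the limit leaves it open whether they differ. Compound 2 has only a limit of the assay, > 100000 nM, so the earlier step has no exact size, and these two pairs cannot show how well the change carries over to other cores.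

From the compounds shown here alone, the selenium and the six-membered aromatic ring enter together in both steps, so it stays open which of them, if either, matters; a benzylsulfanyl group or a methylselanyl group on the same carbon would separate the two. Also open, going by these compounds, is how a group of another kind in that place, such as an amine, would read in this assay.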